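Removing a chloro between two ring nitrogens of compound 2

The source may hold more compounds than are shown below. What is called first, only, known or untested is meant among the compounds shown, and "the series" means these compounds.

Measured compounds:
compound 1 `ClCc1ccc(Cn2cnc3c(Cl)ncnc32)cc1` gives 3540 nM
compound 2 `ClCc1ccccc1Cn1cnc2c(Cl)nc(Cl)nc21` gives 510 nM

In a functional assay on OVCAR-3 cells (Homo sapiens) for cytotoxicity, read by sulforhodamine B assay, with a stated time of 48 h (a higher number here means a weaker inhibitor of growth, a lower number a stronger inhibitor of growth), compound 2, with the structure `ClCc1ccccc1Cn1cnc2c(Cl)nc(Cl)nc21`, gives 510 nM. Compound 1, with the structure `ClCc1ccc(Cn2cnc3c(Cl)ncnc32)cc1`, gives 3540 nM in this assay. Of the two numbers, that of compound 2 is the lower, and the gap to compound 1 lies beyond the scatter of repeated measurements. The step considered here leads from compound 2 to compound 3, whose structure is `ClCc1ccccc1Cn1cnc2c(Cl)ncnc21`. The change is hydrogen in place of chloro on an aromatic carbon. Going by the values given here, no step between measured compounds shows this change on its own; compound 1 also lacks the chloro but differs in the benzyl part too. Compound 3 is expected to give a higher number than compound 2 in this assay, a step of a 2.4-fold higher number from compound 2 to compound 3 (0.37 log units; beyond the scatter) that goes somewhat beyond the scatter. For compound 3 the estimate is 1200 nM, with a range from 400 nM to 4000 nM.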

Compound 3, concentration for total growth inhibition: 3540 nM
Compound 3: the middle estimate sits 3.0-fold (0.47 log units) below what was measured, within the range that was stated.
By their numbers in this assay, from the lowest: compound 2; then compounds 1 and 3 (each within the scatter of the next).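

In this assay, hydrogen in place of chloro on the aromatic carbon between two ring nitrogen atoms gives a 6.9-fold higher number from compound 2 to compound 3 (0.84 log units; beyond the scatter). Going by these compounds alone, compound 2 and compound 3 differ in this one place only, so this step shows for the first time that the chloro on this carbon matters on its own, with its loss giving a weaker inhibitor of growth. Nothing measured here bears on the reason for this rise.

The compounds shown leave open whether another group on this carbon, such as fluoro, methoxy or an amine, would give a number nearer that of compound 2 or that of compound 3. They also leave open whether the same change would give a step of similar size on the benzyl part of compound 1.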